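The compounds below may be only part of what the source reports. "The series", "measured", "known", "first", "only" and "open" are said of these compounds alone.

Measured so far, in an ADME assay on THP-1 cells (Homo sapiens) for cytotoxicity; on this read-out higher numbers stand for lower toxicity in this test and lower numbers for higher toxicity in this test:
Compound 1 `COc1ccc(-n2cc(COc3ccc(/C=N/Nc4nc(-c5ccc([N+](=O)[O-])cc5)cs4)cc3)nn2)cc1` gives 37900 nM.
Compound 2 `COc1ccc(-n2cc(COc3ccc(/C=N/Nc4nc(-c5ccc(C)cc5)cs4)cc3)nn2)cc1` gives 40300 nM.

Compound 2 and compound 1 lie close together: the change a 1.1-fold higher number from compound 1 to compound 2 (0.03 log units; within the scatter) did not reach beyond the scatter. Compound 3 `COc1ccc(-n2cc(COc3ccc(/C=N/Nc4nc(-c5cc6ccccc6oc5=O)cs4)cc3)nn2)cc1` is the next step from compound 2, with a group of 11 heavy atoms (9 carbon, 2 oxygen; one six-membered aromatic ring of carbon only, one six-membered aromatic ring with 1 hetero atom) in place of a group of 7 heavy atoms (7 carbon; one six-membered aromatic ring of carbon only), on an aromatic carbon; this sits on an aromatic carbon of the five-membered ring with one nitrogen and one sulfur, next to the ring nitrogen. Going by the values given here, only one measured step bears on it, the swap from compound 1 to compound 2 at the same end of the molecule, and it stayed within the scatter. The entering group is larger, but the data give no reason to expect a step beyond the scatter. Compound 3 is therefore expected to give 35000 nM, with a range from 15000 nM to 80000 nM. The expected step is a 1.2-fold lower number from compound 2 to compound 3 (0.06 log units; within the scatter).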

Compound 3, half-maximal cytotoxic concentration: 36300 nM
For compound 3 the middle estimate is 1.0-fold (0.02 log units) below the measured one; the measured number falls inside the stated range.
By their numbers in this assay, from the lowest: compounds 3, 1 and 2 (each within the scatter of the next).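

In this assay, the position next to the ring nitrogen also accepts a larger group with two rings and 2 hydrogen-bond acceptors in place of 4-methylphenyl, with a 1.1-fold lower number from compound 2 to compound 3 (0.05 log units; within the scatter) as the result. Against the nitro-bearing group, the same swap gives a 1.0-fold lower number from compound 1 to compound 3 (0.02 log units; within the scatter) and so all three groups read alike here. No outside measurement bears on this result.

Still open, going by these compounds, is whether a group of another kind at this position, such as an amine or a carboxylic acid, would move the number beyond the scatter.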